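Thiophene in place of nitrophenyl on a pyrrole-based anti-inflammatory core

A few compounds are considered here, and "the series" means these few. Any claim that something is new, unique, unknown or untested is made for them only; others in the source may bear on it.

Compound 2 `O=C(O)c1cc(-n2c(-c3ccc([N+](=O)[O-])cc3)cc3c2CCCC3)ccc1O` carries a 4-nitrophenyl group on its core and gives 30% in a functional assay on the whole organism (strain Wistar) for inhibition, with Rattus norvegicus as the target, read by paw edema, with stated times of 30 min and 3 h, at a dose of 200 mg/kg by the oral route; on this read-out higher numbers stand for more inhibition at the one dose given (going by the name of the read-out) and lower numbers for less inhibition. Its nearest measured neighbour is compound 1 `Cc1ccc(-c2cc3c(n2-c2ccc(O)c(C(=O)O)c2)CCCC3)cc1`, which bears methyl in place of nitro on that aromatic carbon and gives 30%; the step of no change at the digits printed from compound 1 to compound 2 (within the scatter) lies within the scatter, so compound 2 stands level with compound 1 on these numbers. Compound 3 `O=C(O)c1cc(-n2c(-c3cccs3)cc3c2CCCC3)ccc1O` differs from compound 2 by thiophen-2-yl in place of 4-nitrophenyl on an aromatic carbon. Among the measured compounds shown here, no measured step concerns an exchange of the whole 4-nitrophenyl group for another aromatic ring; the one step that exists, from methyl to nitro on that ring, showed no change beyond the scatter. On that basis compound 3 is expected to stay close to compound 2, with a step of no change at the digits printed from compound 2 to compound 3 (within the scatter) of no clear direction. The estimate for compound 3 is 30%, with a range from 15% to 45%.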

Compound 3, a percentage reported as inhibition, in the whole organism at one dose (the size of the read-out at that dose, not a potency): 30%
For compound 3 middle estimate and measured number coincide at the digits printed, within the range that was stated.
By their numbers in this assay, from the lowest: compounds 1, 2 and 3 (each within the scatter of the next).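

The exchange of a whole aromatic group on this carbon next to the ring nitrogen now has a reading, where earlier only a substituent on the phenyl ring had changed. In this assay, thiophen-2-yl in place of 4-nitrophenyl gives no change at the digits printed from compound 2 to compound 3 (within the scatter), and thiophen-2-yl in place of 4-methylphenyl gives no change at the digits printed from compound 1 to compound 3 (within the scatter). The place therefore takes a five-membered aromatic ring with a sulfur atom as well as either substituted phenyl ring without a step beyond the scatter, and nothing available accounts for this sameness.

On these data alone, all three groups at this place are aromatic rings, so it remains open how a cyclohexyl ring or a short alkyl chain would read there. With a single dose, the compounds also leave open whether potency differs among them.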